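The source may report more compounds than this note shows. Statements on the series, on what has been measured and on what is new or still open speak of the compounds shown alone.

Compound 1: `Cc1nc(Nc2ccc(Cl)cc2)sc1C(=O)/C=C/c1ccccc1` — > 25000 nM
Compound 2: `COc1cccc(/C=C/C(=O)c2sc(Nc3ccc(Cl)cc3)nc2C)c1` — > 25000 nM

In a functional assay on Bel-7402 cells (Homo sapiens) for cytotoxicity, read by MTT assay (a lower number here means a stronger inhibitor, a higher number a weaker inhibitor), compound 1 gives > 25000 nM, which is a limit of the assay rather than a number. Compound 2 likewise gives > 25000 nM, again a limit and not a measured number. The step between them, a step that the two limits leave unreadable from compound 1 to compound 2, therefore cannot be read, because both values sit where the limit of > 25000 nM in this assay, at which 2 of the 2 values shown sit, describes. Compound 2 thus stands at the limit, with no number of its own, and nothing closer is known about it.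

Compound 3, `COc1cccc(/C=C/C(=O)c2sc(Nc3ccc(C)cc3)nc2C)c1`, differs from compound 2 by methyl in place of chloro on an aromatic carbon. Going by the values given here, the only measured step, a step that the two limits leave unreadable from compound 1 to compound 2, concerns a different part of the molecule and has no readable size, so it gives no guide to the direction or size of this change. With both measured compounds sitting at the limit, the expectation for compound 3 is that it stays there as well, and the step that the limit leaves unreadable from compound 2 to compound 3 is expected to be small. Compound 3 is expected to give about 40000 nM in this assay, within a range of 15000 nM to 150000 nM, and most likely to be reported only as a limit.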

Compound 3, half-maximal inhibitory concentration: > 25000 nM
Compound 3 gave a limit, no number (the forecaster's own chance of this, stated with the estimate: 80%); the middle value lies beyond the limit too.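

In this assay compound 3 gives > 25000 nM as a limit and not a number, so the step from compound 2 to compound 3 cannot be read, just as the step from compound 1 to compound 2 could not: the limit of > 25000 nM in this assay, at which 3 of the 3 values shown sit. The compounds shown leave open how strong each one really is, and whether either swap changes cytotoxicity at all.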